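Swapping a dichlorophenoxy for a fluorophenylthio group

The source may hold more compounds than are shown below. What is called first, only, known or untested is meant among the compounds shown, and "the series" means these compounds.

Measured so far:
compound 1 `Nc1cc(N)c2nc(-c3ccccc3)c(Oc3ccc(Cl)c(Cl)c3)nc2c1`: 91200 nM
compound 2 `Nc1cc(N)c2nc(-c3ccccc3)c(NCc3ccc(Cl)c(Cl)c3)nc2c1`: 29500 nM
compound 3 `CCOC(=O)[C@H](CCC(=O)O)NC(=O)c1ccc(Sc2nc3cc(N)cc(N)c3nc2-c2ccccc2)cc1`: a limit only, < 100000 nM

In a functional assay on IGROV-1 cells (Homo sapiens) for inhibition, read by sulforhodamine B assay, with a stated time of 48 h (on this read-out higher numbers stand for lower toxicity in this test and lower numbers for higher toxicity in this test), compound 1 gives 91200 nM, the highest of the two numbers, with compound 2 nearest at 29500 nM, a gap beyond the usual scatter. Compound 3 reaches only a limit of the assay, < 100000 nM. Compound 4 `Nc1cc(N)c2nc(-c3ccccc3)c(Sc3ccc(F)cc3)nc2c1` has not been measured; it differs from compound 1 by (4-fluorophenyl)sulfanyl in place of 3,4-dichlorophenoxy on an aromatic carbon. For the measured compounds named here, no measured pair separated by a single change is available, so the size of this step rests on the spread of the three results alone, all of them at high concentrations. The expected step, a 1.5-fold lower number from compound 1 to compound 4 (0.18 log units; within the scatter), is small in this assay and could go either way. Compound 4 is estimated at 60000 nM, between 20000 nM and 150000 nM.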

Compound 4, concentration lethal to 50% of the cells: < 100000 nM
Compound 4: only a limit was reported; the forecaster's own chance of this, stated with the estimate: 25%; the middle value lies beyond the limit too.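

The step from compound 1 to compound 4 cannot be read, because compound 4 gave only a limit: the limit of < 100000 nM in this assay, at which 2 of the 4 values shown sit. Going by these compounds, whether (4-fluorophenyl)sulfanyl in place of 3,4-dichlorophenoxy changes toxicity in this test at all stays open.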